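The source may hold more compounds than are shown below. What is called first, only, known or untested is meant among the compounds shown, and "the series" means these compounds.

In a functional assay, with a stated time of 19 h (a lower number here means a stronger inhibitor, a higher number a weaker inhibitor), three close analogues have been measured so far. Compound 1 `CN(C)Cc1cc(/C=C/C(=O)/C=C(O)/C=C/c2ccc(Cl)cc2)ccc1O` gives 41100 nM. Compound 2 `COc1ccc(/C=C/C(O)=C/C(=O)/C=C/c2ccc(O)c(CN(C)C)c2)cc1` gives 11900 nM, and compound 3 `COc1ccc(/C=C/C(O)=C/C(=O)/C=C/c2ccc(O)c(CN(C)C)c2)cc1OC` gives 27400 nM. Compound 3 therefore stands second highest of the three numbers: it sits nearest to compound 1, with a 1.5-fold lower number from compound 1 to compound 3 (0.18 log units; within the scatter), and furthest from compound 2, with a 2.3-fold higher number from compound 2 to compound 3 (0.36 log units; beyond the scatter). The remaining step between the measured compounds is a 3.5-fold lower number from compound 1 to compound 2 (0.54 log units; beyond the scatter).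

Compound 4 `CN(C)Cc1cc(/C=C/C(=O)/C=C(O)/C=C/c2cccc(O)c2)ccc1O` has not yet been measured. It differs from compound 3 in one place: 3-hydroxyphenyl in place of 3,4-dimethoxyphenyl on a double-bonded chain carbon bound to a double-bonded chain carbon. Among the measured compounds shown here, two measured steps bear on this change. The step of a 2.3-fold higher number from compound 2 to compound 3 (0.36 log units; beyond the scatter) shows what an added methoxy on an aromatic carbon did, and compound 4 gives up that second methoxy, so the reverse of that step would be expected to lower the number. For the measured compounds named here, what a hydroxy in place of a methoxy does, no measured pair here shows; the step of a 3.5-fold lower number from compound 1 to compound 2 (0.54 log units; beyond the scatter) only indicates that exchanging the group on this ring can shift the number modestly. On that basis, in this assay compound 4 is expected to give about 12000 nM, with a range from 4000 nM to 35000 nM. This expectation corresponds to a 2.3-fold lower number from compound 3 to compound 4 (0.36 log units; beyond the scatter).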

Compound 4, half-maximal inhibitory concentration: 6900 nM
Beside the measured number, compound 4's estimate is 1.7-fold (0.24 log units) above it; the measured number falls inside the stated range.
By their numbers in this assay, from the lowest: compounds 4 and 2 (each within the scatter of the next); then compounds 3 and 1 (each within the scatter of the next).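

In this assay, among the compounds shown here, 3-hydroxyphenyl is the only group at this place counted with a hydrogen-bond donor, and exchanging 3,4-dimethoxyphenyl for it gives a 4.0-fold lower number from compound 3 to compound 4 (0.60 log units; beyond the scatter) in what is a larger shift than the removal of one methoxy had suggested. For the compounds shown here, the exchange for 4-chlorophenyl gives a 6.0-fold lower number from compound 1 to compound 4 (0.77 log units; beyond the scatter) as the widest gap among the four compounds, so this place on the shared core tolerates changes that move the number by more than the earlier compounds showed. Against the 4-methoxyphenyl group, however, the same hydroxy-bearing ring gives a 1.7-fold lower number from compound 2 to compound 4 (0.24 log units; within the scatter) and so cannot be told apart from it, which means that a hydrogen-bond donor on this ring is not needed to reach the lower numbers seen here, as the 4-methoxyphenyl group of compound 2 shows.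

The compounds shown leave open whether the hydroxy group's place on the ring matters, and how a 4-hydroxyphenyl, an aminophenyl or a carboxyphenyl group would compare on this double-bonded chain carbon. Nothing available accounts for the size of these steps.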